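Swapping a pyrazole for an imidazole on the Mer inhibitor core

The source may hold more compounds than are shown below. What is called first, only, known or untested is meant among the compounds shown, and "the series" means these compounds.

Of the compounds shown here, three sharing one core have been tested in an assay on isolated protein for inhibition of tyrosine-protein kinase Mer (Homo sapiens), read by LC-MS; on this read-out lower numbers stand for stronger inhibition and higher numbers for weaker inhibition. Compound 1 `CN(Cc1ccc2nccn2c1)c1nnc(-c2ccc(C3CC3)cc2)o1` gives 794 nM. Compound 2 `Cc1ncccc1-c1ccc(-c2nnc(N(C)Cc3ccc4nccn4c3)o2)cc1` gives 50.1 nM, and compound 3 `Cc1cc(-c2c(C)n[nH]c2C)ccc1-c1nnc(N(C)Cc2ccc3nccn3c2)o1` gives 39.8 nM. Compound 3 therefore sits at the low end of the three numbers, side by side with compound 2, whose value is within the usual scatter of its own, while compound 1 lies far above both.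

For the measured compounds named here, the only single-point step measured so far is a 16-fold lower number from compound 1 to compound 2 (1.20 log units; beyond the scatter), which shows that placing an aromatic heterocycle on the outer ring in place of cyclopropyl gives a large gain. Compound 2 and compound 3 both carry such a heterocycle and give similar numbers.

Compound 4 `Cc1cc(-c2c(C)nc(C)n2C)ccc1-c1nnc(N(C)Cc2ccc3nccn3c2)o1` differs from compound 3 by one change: 1,2,4-trimethyl-1H-imidazol-5-yl in place of 3,5-dimethyl-1H-pyrazol-4-yl on an aromatic carbon. Going by the values given here, no measured step covers this swap of one five-membered aromatic ring for another of the same kind. Since compound 2 and compound 3 both give low values with different heterocycles at this position, the step is expected to be small, a 1.4-fold higher number from compound 3 to compound 4 (0.15 log units; within the scatter), most likely within the scatter. Compound 4 is thus estimated at 56 nM in this assay, with a plausible range from 20 nM to 160 nM.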

Compound 4, half-maximal inhibitory concentration: 39.8 nM
Compound 4: middle estimate off by 1.4-fold (0.15 log units), on the high side, within the range that was stated.
By their numbers in this assay, from the lowest: compounds 3, 4 and 2 (each within the scatter of the next); then compound 1.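

In this assay there is no change at the digits printed from compound 3 to compound 4 (within the scatter) when 1,2,4-trimethyl-1H-imidazol-5-yl takes the place of 3,5-dimethyl-1H-pyrazol-4-yl, even though the ring that enters has 0 hydrogen-bond donors against 1 in the ring that leaves, and 2 hydrogen-bond acceptors against 1. For this pair, then, the hydrogen-bond donor of the leaving ring is not needed to hold the number, and the position accepts a group of 8 heavy atoms in place of one of 7 with no shift beyond the usual scatter. Nothing available here explains why the two rings give the same number.

Both rings are five-membered aromatic rings carrying methyl groups, so the compounds shown leave open whether those methyl groups matter, a question that an unsubstituted imidazole would address. They also leave open how this position responds to a group of a different kind, such as a morpholine, a piperazine or a carboxylic acid, in place of the aromatic ring.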